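The source may report more compounds than this note shows. Statements on the series, on what has been measured and on what is new or still open speak of the compounds shown alone.

Of the compounds shown here, three have been measured so far in a functional assay on SW 1116 cells (Homo sapiens) for cytotoxicity, read by MTT assay, with a stated time of 24 h, tested at 0.1 ug/mL; on this read-out lower numbers stand for a stronger effect and higher numbers for a weaker effect at the one concentration tested. Compound 1 `CC1(C)CC(=O)C2=C(C1)OC(=O)C(NC(=O)c1ccccc1)C2c1ccc([N+](=O)[O-])cc1` gives 107%, compound 2 `CC1(C)CC(=O)C2=C(C1)OC(=O)C(NC(=O)c1ccccc1)C2c1cccs1` gives 94.5%, and compound 3 `O=C1CCCC2=C1C(c1ccco1)C(NC(=O)c1ccccc1)C(=O)O2` gives 95.5%. Among these three numbers compound 3 stands second highest: its nearest neighbour is compound 2, which lies within the usual scatter of it, while compound 1 is further away, above it by a margin beyond the scatter.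

Compound 4 `O=C1CCCC2=C1C(c1cccs1)C(NC(=O)c1ccccc1)C(=O)O2` is not yet measured. It differs from compound 3 in one place: thiophen-2-yl in place of furan-2-yl on a saturated ring carbon.

Among the measured compounds shown here, the only measured step that changes the group on this saturated ring carbon is a number 12.5 percentage points lower from compound 1 to compound 2 (beyond the scatter), but there thiophen-2-yl replaced 4-nitrophenyl, not furan-2-yl. For the measured compounds named here, for furan-2-yl against thiophen-2-yl directly, no step is recorded; the two values available for compounds bearing these groups, compound 2 and compound 3, are within the scatter of one another, though their cores also differ. On this footing no step beyond the scatter is expected in this assay.

Compound 4 is therefore estimated at 95%, within 85% to 105%, which means an expected step of a number 0.5 percentage points lower from compound 3 to compound 4 (within the scatter).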

Compound 4, a percentage reported as activity, at one concentration (the size of the read-out at that concentration, not a potency): 80%
Compound 4: the middle estimate sits 15 percentage points above what was measured; the whole stated range lies above it.
By their numbers in this assay, from the lowest: compound 4; then compounds 2 and 3 (each within the scatter of the next); then compound 1.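

Among the compounds shown here, exchanging furan-2-yl for thiophen-2-yl on this saturated ring carbon, with the rest of the molecule unchanged, gives the first direct comparison of these two groups, and in this assay it produces a number 15.5 percentage points lower from compound 3 to compound 4 (beyond the scatter). The two groups have the same heavy-atom count and the same hydrogen-bond counts, and each is a five-membered aromatic ring with one hetero atom, yet sulfur in place of oxygen is enough here for a step beyond the scatter, so this position distinguishes between them. Thiophen-2-yl also enters in the other recorded step at this carbon, a number 12.5 percentage points lower from compound 1 to compound 2 (beyond the scatter), where it replaces 4-nitrophenyl on a different core, so both steps run the same way, but nothing at hand explains the change seen with compound 4.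

From the compounds shown here alone, it remains open whether furan-2-yl and thiophen-2-yl differ in the same way on the core of compound 2, and how a plain phenyl or a pyridine ring on this carbon would read. Each of these compounds is also shown at one concentration only, so it is unknown whether the step between compound 3 and compound 4 persists at higher concentrations.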